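Swapping furan-3-yl for 1,2-thiazol-5-yl

This account rests on a few compounds, and the source may have more. Where it says the series, first, only, none or still open, it means among the compounds named here.

Of the compounds shown here, three built on one shared core have been measured in a functional assay for activation of Alpha-1B adrenergic receptor (Homo sapiens), read by calcium flux; a lower number here means that less compound is needed, a higher number that more compound is needed for the effect. Compound 1 `c1coc(-c2ccccc2OCC2=NCCN2)c1` gives 10 nM, compound 2 `c1c[nH]c(-c2ccccc2OCC2=NCCN2)c1` gives 1 nM, and compound 3 `c1ccc(-c2ccoc2)c(OCC2=NCCN2)c1` gives 5.01 nM. Compound 3 therefore holds the second highest of the three numbers; its nearest neighbour is compound 1, a 2.0-fold lower number from compound 1 to compound 3 (0.30 log units; within the scatter), a gap within the scatter, while compound 2 lies furthest away, a 5.0-fold higher number from compound 2 to compound 3 (0.70 log units; beyond the scatter).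

Compound 4 `c1ccc(-c2ccns2)c(OCC2=NCCN2)c1` has not yet been measured. It differs from compound 3 in a single place: 1,2-thiazol-5-yl in place of furan-3-yl on an aromatic carbon.

For the measured compounds named here, two measured steps bear on this change. Putting furan-3-yl in place of furan-2-yl, a 2.0-fold lower number from compound 1 to compound 3 (0.30 log units; within the scatter), moved nothing beyond the scatter. Putting 1H-pyrrol-2-yl in place of furan-2-yl did more, a 10-fold lower number from compound 1 to compound 2 (1.00 log units; beyond the scatter). The step to compound 4 again exchanges one five-membered aromatic ring for another, yet the entering ring carries no hydrogen-bond donor, so the step that set compound 2 apart is no direct guide. The chemist therefore expects a step no larger than the scatter, a 1.0-fold lower number from compound 3 to compound 4 (0.00 log units; within the scatter). For compound 4 his estimate in this assay is 5 nM, within a range from 1.5 nM to 16 nM.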

Compound 4, half-maximal effective concentration: 12.6 nM
Compound 4: middle estimate off by 2.5-fold (0.40 log units), on the low side; the range from low to high includes it.
By their numbers in this assay, from the lowest: compound 2; then compounds 3, 1 and 4 (each within the scatter of the next, the first and the last beyond it).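

In this assay, the change to 1,2-thiazol-5-yl shows that exchanging one five-membered aromatic ring for another with no hydrogen-bond donor on either side can still move the number beyond the scatter (a 2.5-fold higher number from compound 3 to compound 4 (0.40 log units; beyond the scatter)), which the exchange of furan-2-yl for furan-3-yl had not done. The new ring, with 2 hetero atoms, stays within the scatter of the furan-2-yl compound (a 1.3-fold higher number from compound 1 to compound 4 (0.10 log units; within the scatter)) but gives the largest step in the set when set against the 1H-pyrrol-2-yl compound (a 13-fold higher number from compound 2 to compound 4 (1.10 log units; beyond the scatter)), so compound 2 still has the lowest number, now with a wider gap above it. No measurement among the data explains why these steps have these sizes.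

The compounds shown leave open whether a thiophene ring, with sulfur as its only hetero atom, or a 1,3-thiazole ring would read like compound 3 or like compound 4 on this aromatic carbon. They also leave open whether an imidazole ring, which keeps a hydrogen on nitrogen alongside a second ring nitrogen, would come close to compound 2.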